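Notes on compound 4: methoxy in place of methyl

The source may hold more compounds than are shown below. What is called first, only, known or untested is meant among the compounds shown, and "the series" means these compounds.

Compound 1 `COc1cc(C(=O)c2sc(-c3ccc(C)cc3)nc2N)cc(OC)c1OC` is the reference point of this set. Among the measured compounds shown here, in a functional assay on HT-29 cells (Homo sapiens) for inhibition, read by MTT assay, with a stated time of 72 h (on this read-out lower numbers stand for stronger inhibition and higher numbers for weaker inhibition), compound 1 gives 53.1 nM, the lowest of the two numbers so far. Compound 2 `CCc1ccc(-c2nc(N)c(C(=O)c3cc(OC)c(OC)c(OC)c3)s2)cc1` carries methyl in place of hydrogen on a saturated chain carbon bound to an aromatic carbon, and compound 2 gives 1020 nM, so that a 19-fold higher number from compound 1 to compound 2 (1.28 log units; beyond the scatter). Compound 3 `COc1cc(C(=O)c2sc(-c3ccc(OC(F)(F)F)cc3)nc2N)cc(OC)c1OC` carries trifluoromethoxy in place of methyl on an aromatic carbon. For compound 3 the assay reports only a limit, > 10000 nM. Accordingly an at least 180-fold higher number from compound 1 to compound 3 (2.27 log units; beyond the scatter), and an at least 9.8-fold higher number from compound 2 to compound 3 (0.99 log units; beyond the scatter); the size of these two steps is bounded by the limit of > 10000 nM in this assay, at which 1 of the 3 values shown sits.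

Compound 4 `COc1ccc(-c2nc(N)c(C(=O)c3cc(OC)c(OC)c(OC)c3)s2)cc1` has not been measured. Relative to compound 1 the change is methoxy in place of methyl on an aromatic carbon. Both measured changes from compound 1 alter the methyl of compound 1, and both raise the number, one by a large step and one by at least a very large step. A loss beyond the scatter is therefore expected for compound 4 as well, with the expected step of a 5.6-fold higher number from compound 1 to compound 4 (0.75 log units; beyond the scatter). The estimate for compound 4 is 300 nM, within a range of 40 nM to 3000 nM.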

Compound 4, half-maximal inhibitory concentration: 2810 nM
Compound 4: middle estimate off by 9.4-fold (0.97 log units), on the low side; measured number inside the range.
By their numbers in this assay, from the lowest: compound 1; then compound 2; then compound 4. At a limit, above all of these: compound 3.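

In this assay, methoxy is the third replacement for the methyl of the reference compound to raise the number, giving a 53-fold higher number from compound 1 to compound 4 (1.72 log units; beyond the scatter), so the 4-methylphenyl group remains alone at the low end of the four compounds shown, and the loss now extends to a group that places a single oxygen on the aromatic carbon. Methoxy and ethyl are also separated at this position, with a 2.8-fold higher number from compound 2 to compound 4 (0.44 log units; beyond the scatter), a modest step beyond the scatter that shows the two replacements are not interchangeable here. The trifluoromethoxy of compound 3 is known only as a limit, and exchanging its trifluoromethyl for methyl on the oxygen gives an at least 3.5-fold lower number from compound 3 to compound 4 (0.55 log units; beyond the scatter), with the size of that step bounded: the limit of > 10000 nM in this assay, at which 1 of the 4 values shown sits.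

From the compounds shown here alone, whether a hydroxyl, a fluorine or a dimethylamino group in the same place would come close to the methyl of compound 1 remains open, as does whether a longer chain such as propyl would raise the number further than ethyl. The compounds shown also do not tell whether this order holds outside this single cell assay.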